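The compounds below may be only part of what the source reports. "The series", "measured", "known", "first", "only" and "open" are said of these compounds alone.

Compound 1 `O=C(CSc1nnc(-c2ccncc2)o1)N/N=C/c1ccc(O)cc1`, compound 2 `COc1ccc(/C=N/NC(=O)CSc2nnc(-c3ccncc3)o2)cc1` and compound 3 `O=C(CSc1nnc(-c2ccncc2)o1)N/N=C/c1ccc(O)c(O)c1` share one core and differ only in the aromatic ring carried by the carbon with a double bond to nitrogen. In a functional assay on MCF7 cells (Homo sapiens) for cytotoxicity, read by MTT assay, with a stated time of 48 h (on this read-out lower numbers stand for stronger inhibition and higher numbers for weaker inhibition), compound 1 gives 11700 nM, compound 2 gives 17600 nM and compound 3 gives 910 nM, the lowest number of the three. The change methyl in place of hydrogen on an oxygen on an aromatic ring made a 1.5-fold higher number from compound 1 to compound 2 (0.18 log units; within the scatter). Compound 3 differs from compound 1 by hydroxy in place of hydrogen on an aromatic carbon, a change that made a 13-fold lower number from compound 1 to compound 3 (1.11 log units; beyond the scatter). Compound 4 `COc1cc(/C=N/NC(=O)CSc2nnc(-c3ccncc3)o2)ccc1O` has not been measured in this assay; it differs from compound 3 by methyl in place of hydrogen on an oxygen on an aromatic ring, the same change that turned compound 1 into compound 2, at a place described in the same words in both pairs. Because a 1.5-fold higher number from compound 1 to compound 2 (0.18 log units; within the scatter) stayed within the scatter, the corresponding step from compound 3 is expected to be modest, and compound 4 is estimated to show a 2.0-fold higher number from compound 3 to compound 4 (0.30 log units; within the scatter). Compound 4 is therefore expected to give about 1800 nM in this assay, most likely between 800 nM and 5000 nM.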

Compound 4, half-maximal inhibitory concentration: 3780 nM
The estimate for compound 4 lay 2.1-fold (0.32 log units) below the measured number, within the range that was stated.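

In this assay, methyl in place of hydrogen on an oxygen on an aromatic ring gave a 4.2-fold higher number from compound 3 to compound 4 (0.62 log units; beyond the scatter), and this change did not keep its size from one core to the other: the same change on two cores in this assay, a 1.5-fold higher number (0.18 log units; within the scatter) from compound 1 to compound 2 and a 4.2-fold higher number (0.62 log units; beyond the scatter) from compound 3 to compound 4, 2.8-fold (0.44 log units) apart, beyond the scatter of two such steps

Adding methoxy to the aromatic ring still gave a 3.1-fold lower number from compound 1 to compound 4 (0.49 log units; beyond the scatter), and 4-hydroxy-3-methoxyphenyl in place of 4-methoxyphenyl gave a 4.7-fold lower number from compound 2 to compound 4 (0.67 log units; beyond the scatter). The size of this step on one core was therefore a poor guide to its size on the other, but two pairs give no rule for further cores and do not show why the two steps differ.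

The compounds shown leave open whether a longer chain on that oxygen, or an amine or a carboxylic acid on the aromatic ring, would give a step of either size. They also leave open whether the gap between the two steps would appear in any other cell line.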